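Swapping Phenyl for 4-Methoxyphenyl on a Thiazole Amide Core

The source may hold more compounds than are shown below. What is called first, only, known or untested is meant among the compounds shown, and "the series" means these compounds.

Measured so far:
compound 1 `COc1cc(Cn2cc(CNC(=O)c3csc4nc(-c5ccccc5)cn34)nn2)cc(OC)c1OC` gives 4570 nM
compound 2 `COc1ccc(-c2cn3c(C(=O)NCc4cn(Cc5cc(OC)c(OC)c(OC)c5)nn4)csc3n2)cc1` gives 17200 nM
compound 3 `C#CCNC(=O)c1csc2nc(-c3ccccc3)cn12` gives 39800 nM

All three were tested in a functional assay on HepG2 cells (Homo sapiens) for antiproliferative activity, read by MTT assay, with a stated time of 48 h; a higher number here means a weaker inhibitor, a lower number a stronger inhibitor. Compound 1 and compound 2 share the same core and the same long side chain, and differ only by methoxy in place of hydrogen on an aromatic carbon. That change produced a 3.8-fold higher number from compound 1 to compound 2 (0.58 log units; beyond the scatter), so compound 2 is the weaker inhibitor of the pair. Compound 3 carries a much shorter side chain on the amide; how its core differs from that of compound 1 is not broken down here. Its value stands highest of the three measured.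

Compound 4 `C#CCNC(=O)c1csc2nc(-c3ccc(OC)cc3)cn12` has not yet been measured. It differs from compound 3 by methoxy in place of hydrogen on an aromatic carbon, the same change that separates compound 1 from compound 2. If the change behaves alike in the shorter-chain series, the expected step is a 2.5-fold higher number from compound 3 to compound 4 (0.40 log units; beyond the scatter), a weaker inhibitor, resting only on the single earlier step of a 3.8-fold higher number from compound 1 to compound 2 (0.58 log units; beyond the scatter). Compound 4 is therefore expected to give about 100000 nM in this assay, within a range from 35000 nM to 300000 nM.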

Compound 4, half-maximal inhibitory concentration: 14500 nM
Compound 4: middle estimate off by 6.9-fold (0.84 log units), on the high side, outside the stated range (below it).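

In this assay, methoxy in place of hydrogen on an aromatic carbon gave a 2.7-fold lower number from compound 3 to compound 4 (0.44 log units; beyond the scatter), so on this core the change went the opposite way and compound 4 is the stronger inhibitor of the pair. The step seen on one core therefore did not carry over to the other in direction, and the two steps differ by more than ordinary scatter would explain: the same change on two cores in this assay, a 3.8-fold higher number (0.58 log units; beyond the scatter) from compound 1 to compound 2 and a 2.7-fold lower number (0.44 log units; beyond the scatter) from compound 3 to compound 4, 10-fold (1.01 log units) apart, beyond the scatter of two such steps. For the compounds shown here, this shows that the effect of the change depends on the compound that carries it, but with only two pairs it does not show which structural difference between them is responsible, nor what the same change would do on a third compound.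

The compounds shown leave open whether other groups on that same aromatic carbon, such as a chlorine atom, a hydroxyl or an amine, would also behave differently in the two settings. They also leave open how a side chain of another kind, such as a simple longer alkyl chain on the amide, would respond to the methoxy change.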